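A Cyano Swap on a Compound Without a Number

A few compounds are considered here, and "the series" means these few. Any claim that something is new, unique, unknown or untested is made for them only; others in the source may bear on it.

In a functional assay on A549 cells (Homo sapiens) for cytotoxicity, read by MTT assay, with a stated time of 72 h (a higher number here means a weaker inhibitor, a lower number a stronger inhibitor), compound 2 `COc1ccc(/C=C/C(=O)Nc2cc3c(Nc4ccc(F)c(Cl)c4)ncnc3cc2OC)cc1` is recorded as "not active" (no number reported), so it offers no number to start from. Compound 4 `COc1cc2ncnc(Nc3ccc(F)c(Cl)c3)c2cc1NC(=O)/C=C/c1ccc(C#N)cc1` differs from it by cyano in place of methoxy on an aromatic carbon. Compound 1 `COc1ccc(/C=C/C(=O)Nc2cc3c(Nc4ccc(F)c(Cl)c4)ncnc3cc2O[C@H]2CCOC2)c(OC)c1` gives 9350 nM and compound 3 `COc1ccc(/C=C/C(=O)Nc2cc3c(Nc4ccc(F)c(Cl)c4)ncnc3cc2O[C@H]2CCOC2)c(OC)c1OC` gives 70 nM. Their step, a 130-fold lower number from compound 1 to compound 3 (2.13 log units; beyond the scatter), is the only measured one. It adds a methoxy rather than exchanging one for cyano, and both compounds differ from compound 2 elsewhere too. It shows that a single change can be large here, but it sets no size or direction for this swap. Weak activity is therefore expected to persist. Compound 4 is estimated at 12000 nM, with an expected range from 2500 nM to 50000 nM.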

Compound 4, half-maximal inhibitory concentration: "not active" (no number reported)
Compound 4 has no reported number here; the estimate stays without a comparison.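

In this assay compound 2 and compound 4 are both recorded as not active, without a number, so no step can be read between them. As far as these compounds go, how far 4-methoxyphenyl to 4-cyanophenyl moves the number stays open, and no supporting evidence bears on this result.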